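The compounds below may be only part of what the source reports. "The series", "measured", "known", "first", "only" and "open" are said of these compounds alone.

Three compounds share the core of compound 1 `COc1ccc(C)cc1N1C(=O)CSC1c1cccc(C(=O)NCCCCc2ccccc2)c1` and differ only in the aryl group on the amide-type nitrogen of the five-membered ring. In a functional assay on SJSA-1 cells (Homo sapiens) for inhibition, read by CCK-8 assay, with a stated time of 72 h, tested at 1 uM (on this read-out higher numbers stand for more inhibition at the one concentration tested (going by the name of the read-out) and lower numbers for less inhibition), compound 1 gives 79%. Compound 2 `COc1ccc(F)cc1N1C(=O)CSC1c1cccc(C(=O)NCCCCc2ccccc2)c1` gives 76% in this assay, and compound 3 `COc1cccc(OC)c1N1C(=O)CSC1c1cccc(C(=O)NCCCCc2ccccc2)c1` gives 72% in this assay. All three numbers fall within the scatter of one another: a number 3 percentage points lower from compound 1 to compound 2 (within the scatter), a number 7 percentage points lower from compound 1 to compound 3 (within the scatter) and a number 4 percentage points lower from compound 2 to compound 3 (within the scatter). Compound 3 therefore stands with the other two, not apart from them.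

Compound 4 `O=C(NCCCCc1ccccc1)c1cccc(C2SCC(=O)N2c2ccccc2F)c1` is not yet measured. It differs from compound 3 by 2-fluorophenyl in place of 2,6-dimethoxyphenyl on an amide-type nitrogen in a ring. For the measured compounds named here, the steps that bear on it are the changes of the same aryl group, a number 7 percentage points lower from compound 1 to compound 3 (within the scatter) and a number 4 percentage points lower from compound 2 to compound 3 (within the scatter), and the exchange of fluoro for methyl, a number 3 percentage points lower from compound 1 to compound 2 (within the scatter); none of them moved this assay beyond the scatter. The expected step is accordingly a number 2 percentage points higher from compound 3 to compound 4 (within the scatter), no change beyond the scatter. Compound 4 is estimated at 74% in this assay, with a range from 60% to 86%.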

Compound 4, a percentage reported as inhibition, at one concentration (the size of the read-out at that concentration, not a potency): 80%
Beside the measured number, compound 4's estimate is 6 percentage points below it; measured number inside the range.
By their numbers in this assay, from the lowest: compounds 3, 2, 1 and 4 (each within the scatter of the next).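

All earlier aryl groups on the amide-type nitrogen carried a methoxy group, whereas 2-fluorophenyl carries none, yet in this assay every step to it stays within the scatter (a number 8 percentage points higher from compound 3 to compound 4 (within the scatter); a number 4 percentage points higher from compound 2 to compound 4 (within the scatter); a number 1 percentage points higher from compound 1 to compound 4 (within the scatter)). A methoxy group on this aryl group is therefore not required to keep the read-out level with the rest of the series, and the position also accepts an aryl group with fewer heavy atoms. Nothing available gives a reason for these numbers.

With all four compounds within the scatter at one concentration, the read-out gives no ranking at this position and says nothing about potency. Still open, as far as these compounds go, is how this position responds to an aryl group bearing an amine or a carboxylic acid, or to a plain butyl chain on the nitrogen.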